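The source may hold more compounds than are shown below. What is called first, only, known or untested is meant among the compounds shown, and "the series" means these compounds.

For the measured compounds named here, compound 2 `CN(C)CCn1cnnc1-c1cc(Oc2ccc(NC(=O)Nc3ccc(F)c(Cl)c3)cc2F)ccn1` gives the lower of the two numbers so far: in a functional assay on HT-29 cells (Homo sapiens) for antiproliferative activity, read by MTT assay, with a stated time of 72 h (a higher number here means a weaker inhibitor, a lower number a stronger inhibitor), compound 2 gives 720 nM, whereas compound 1 `CN(C)CCn1cnnc1-c1cc(Oc2ccc(NC(=O)Nc3cccc(C(F)(F)F)c3)cc2F)ccn1` gives 1470 nM. Going by the values given here, the one measured step, a 2.0-fold lower number from compound 1 to compound 2 (0.31 log units; beyond the scatter), shows that swapping the aryl group on the urea nitrogen moves the number by a modest amount. Compound 3 `CN(C)CCn1cnnc1-c1cc(Oc2ccc(NC(=O)Nc3ccc(Cl)cc3Cl)cc2F)ccn1` carries 2,4-dichlorophenyl in place of 3-chloro-4-fluorophenyl on an amide-type nitrogen. Among the compounds with values here, only that step bears on the change, and it was modest, so a modest shift in this assay is expected, most plausibly toward a higher number. For compound 3 the estimate is 1200 nM, with a range of 500 nM to 3000 nM, corresponding to an expected step of a 1.7-fold higher number from compound 2 to compound 3 (0.22 log units; within the scatter).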

Compound 3, half-maximal inhibitory concentration: 1890 nM
Estimate against measurement, compound 3: 1.6-fold (0.20 log units) below; measured number inside the range.
By their numbers in this assay, from the lowest: compound 2; then compounds 1 and 3 (each within the scatter of the next).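

The aryl group on this amide-type nitrogen separates the three compounds only partly. The 2,4-dichlorophenyl group gives up the lower number seen with 3-chloro-4-fluorophenyl (a 2.6-fold higher number from compound 2 to compound 3 (0.42 log units; beyond the scatter)), whereas it remains within the scatter of 3-(trifluoromethyl)phenyl in this assay (a 1.3-fold higher number from compound 1 to compound 3 (0.11 log units; within the scatter)). No measurement here accounts for these differences.

Still open, on these data alone, is whether 3-chlorophenyl or 4-fluorophenyl alone would match the number of compound 2. As far as these compounds go, it is also open how an unsubstituted phenyl or a pyridyl group on the same nitrogen would compare.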